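Swapping Difluorophenyl for Dihydroxyphenyl on a Shared Core

The source may hold more compounds than are shown below. What is called first, only, known or untested is meant among the compounds shown, and "the series" means these compounds.

In a functional assay on MCF-A cells (Homo sapiens) for cytotoxicity (on this read-out lower numbers stand for stronger inhibition of growth and higher numbers for weaker inhibition of growth), compound 2 `CSc1ccc(C2=C(c3ccc(F)c(F)c3)C(=O)N3CCCC3C2)cc1` gives 800 nM as the lower of two numbers, and compound 1 `COc1ccc(C2=C(c3ccc(SC)cc3)CC3CCCN3C2=O)cc1Br` gives 6000 nM as the higher. The change to compound 3 `CSc1ccc(C2=C(c3ccc(O)c(O)c3)C(=O)N3CCCC3C2)cc1` is 3,4-dihydroxyphenyl in place of 3,4-difluorophenyl on a double-bonded ring carbon on a double-bonded ring carbon. For the measured compounds named here, the one measured step at this place is a 7.5-fold lower number from compound 1 to compound 2 (0.88 log units; beyond the scatter) and put 3,4-difluorophenyl in place of 3-bromo-4-methoxyphenyl, so a step of similar size is expected in this assay here, towards a higher number, although nothing measured fixes the direction. The expected move is a 2.5-fold higher number from compound 2 to compound 3 (0.40 log units; beyond the scatter) in this estimate. Compound 3 is estimated at 2000 nM with 400 nM to 8000 nM as its range.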

Compound 3, concentration for 50% growth inhibition: 80000 nM
Beside the measured number, compound 3's estimate is 40-fold (1.60 log units) below it, and the stated range ends below it.
By their numbers in this assay, from the lowest: compound 2; then compound 1; then compound 3.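

Placing 3,4-dihydroxyphenyl on the double-bonded ring carbon gives a 100-fold higher number from compound 2 to compound 3 (2.00 log units; beyond the scatter) in this assay and shows that this position is highly sensitive to what the phenyl ring carries, even with the same number of heavy atoms. The same group also gives a 13-fold higher number from compound 1 to compound 3 (1.12 log units; beyond the scatter) and so ranks last of the three groups shown, which makes the position's tolerance narrower than the earlier pair could reveal. No evidence available here explains this loss.

Still open, from the compounds shown here alone, is whether 4-hydroxyphenyl, with one hydroxyl group, would lie closer to compound 2 or compound 3. The same question applies to 3,4-dimethoxyphenyl.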